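Replacing 2-methoxyphenyl in compound 3: working notes

The source may hold more compounds than are shown below. What is called first, only, known or untested is meant among the compounds shown, and "the series" means these compounds.

Measured so far in a functional assay on the whole organism for inhibition, with Rattus norvegicus as the target; on this read-out lower numbers stand for an effect already at smaller amounts and higher numbers for an effect only at larger amounts of compound:
compound 1 `CC(C)c1ccc(OC(C)(Cc2ccc(Cl)cc2)C(=O)O)cc1`: 1 mg/kg; 1 mg/kg; 1 mg/kg (3 entries)
compound 2 `Cc1ccc(CC(C)(Oc2ccc(C(C)C)cc2)C(=O)O)cc1`: < 1 mg/kg, a limit
compound 3 `COc1ccccc1CC(C)(Oc1ccc(C(C)C)cc1)C(=O)O`: > 10 mg/kg, a limit

Compound 3 stands at the limit of > 10 mg/kg in this assay, at which 1 of the 3 values shown sits. That is a limit and not a number, so its true place on the scale is open.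

The next compound is compound 4 `CC(C)c1ccc(OC(C)(Cc2ccc(Cl)c(Cl)c2)C(=O)O)cc1`, with 3,4-dichlorophenyl in place of 2-methoxyphenyl on a saturated chain carbon, two bonds along the chain from a carbonyl carbon and an oxygen on an aromatic ring.

Within the data shown here, one measured step bears directly on this change: an at least 10-fold higher number from compound 2 to compound 3 (1.00 log units; beyond the scatter). It lies beyond the scatter, and there 2-methoxyphenyl is the entering group. The change to compound 4 removes that same group, so it is expected to run the opposite way, towards a lower number in this assay. The group entering compound 4 also carries chlorine, and compound 1, with chlorine in the same part of the molecule, gives 1 mg/kg; 1 mg/kg; 1 mg/kg (3 entries). That value is the best guide to where the new compound should land.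

The expected change is an at least 10-fold lower number from compound 3 to compound 4 (1.00 log units; beyond the scatter), of similar size to the measured step and beyond the scatter. The estimate for compound 4 is 1 mg/kg, with an expected range from 0.3 mg/kg to 4 mg/kg.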

Compound 4, dose for half-maximal effect: 5 mg/kg
The estimate for compound 4 lay 5.0-fold (0.70 log units) below the measured number, outside the stated range (above it).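

In this assay, 3,4-dichlorophenyl on a saturated chain carbon, two bonds along the chain from a carbonyl carbon and an oxygen on an aromatic ring, gives a measured number where 2-methoxyphenyl gives only a limit, but the change can be read only as a floor that does not clear the scatter (an at least 2.0-fold lower number from compound 3 to compound 4 (0.30 log units; that floor lies within the scatter)). From the compounds shown here alone, the size of that step stays open because compound 3 sits at a limit: the limit of > 10 mg/kg in this assay, at which 1 of the 4 values shown sits. The comparison with 4-methylphenyl is firmer, with an at least 5.0-fold higher number from compound 2 to compound 4 (0.69 log units; beyond the scatter) showing that this position separates the two groups beyond the scatter, and the printed values, compound 1 at 1 mg/kg; 1 mg/kg; 1 mg/kg (3 entries) and compound 4 at 5 mg/kg, show that the figure for the chlorine-bearing compound 1 does not simply carry over to 3,4-dichlorophenyl.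

Going by these compounds, the exact values of compound 2 and compound 3 remain open, so the full span of this position in this assay cannot be stated. Also open, on these data alone, is how a pyridine ring or an amine on the phenyl ring would read at this place.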